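A few compounds are considered here, and "the series" means these few. Any claim that something is new, unique, unknown or untested is made for them only; others in the source may bear on it.

Measured compounds:
Compound 1 `CNC(=O)c1ccc(-c2cnc(NCc3c(F)ccc4c3CCO4)c3cn[nH]c(=O)c23)c(C)n1` — 2.9
Compound 2 `CN(C)Cc1ccc2c(c1)CN(c1cnc(NCc3c(F)ccc4c3CCO4)c3cn[nH]c(=O)c13)C2=O` — 2.2
Compound 3 `Cc1nc(C(=O)N(C)C)ccc1-c1cnc(NCc2c(F)ccc3c2CCO3)c2cn[nH]c(=O)c12` — 2.1

In a physicochemical assay for lipophilicity, using the shake flask method, in phosphate buffer, measured as octanol-water partition, with a stated time of 30 min, at pH 7.4 (a higher number here means a more lipophilic compound, a lower number a more polar compound), compound 1 gives 2.9 and stands highest of the three numbers. Compound 2 gives 2.2, and compound 3 gives 2.1; both sit clearly lower than compound 1, beyond the scatter. Among the measured compounds shown here, the only step between measured compounds that differ in one place is a number 0.80 log units lower from compound 1 to compound 3 (beyond the scatter), brought about by a methyl in place of hydrogen on an amide-type nitrogen.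

Compound 4 `Cc1nn(C)cc1-c1cnc(NCc2c(F)ccc3c2CCO3)c2cn[nH]c(=O)c12` has not yet been measured in this assay. It differs from compound 1 by 1,3-dimethyl-1H-pyrazol-4-yl in place of 2-methyl-6-(methylcarbamoyl)pyridin-3-yl on an aromatic carbon. For the measured compounds named here, none of the measured steps touches this exchange: the step from compound 1 to compound 3 alters only the amide nitrogen of the group that here leaves altogether, and compound 2 replaces the same group with a different one. With the entering group carrying no hydrogen-bond donor and fewer heavy atoms, no directed step beyond the scatter is anticipated.

Compound 4 is therefore expected to give roughly 3, within 2.4 to 3.6, which amounts to an expected step of a number 0.10 log units higher from compound 1 to compound 4 (within the scatter).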

Compound 4, distribution coefficient: 2.8
Compound 4: middle estimate off by 0.20 log units, on the high side, and the stated range covers the measured number.
By their numbers in this assay, from the lowest: compounds 3 and 2 (each within the scatter of the next); then compounds 4 and 1 (each within the scatter of the next).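

Measured in this assay the exchange of 2-methyl-6-(methylcarbamoyl)pyridin-3-yl for 1,3-dimethyl-1H-pyrazol-4-yl on this aromatic carbon gives a number 0.10 log units lower from compound 1 to compound 4 (within the scatter) even though the whole group is replaced, going from 11 heavy atoms to 7, from a six-membered to a five-membered aromatic ring, and from 1 hydrogen-bond donor to 0. The step of a number 0.80 log units lower from compound 1 to compound 3 (beyond the scatter) comes from a change at the amide nitrogen alone, so at this position the size of the exchange and the size of the step do not run together across these two pairs. Nothing at hand explains this difference between the two steps. The compounds shown leave open how the number would respond to an amine or a carboxylic acid on the 1,3-dimethyl-1H-pyrazol-4-yl group. They also leave open what a longer chain in place of either of its methyl groups would do.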